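Sulfonamide piperidine series: amide to oxazole swap

A few compounds are considered here, and "the series" means these few. Any claim that something is new, unique, unknown or untested is made for them only; others in the source may bear on it.

Measured so far:
compound 1 `CCN(CC)S(=O)(=O)c1ccc(S(=O)(=O)N2CCC[C@@H](C(=O)N(C)C(C)C)C2)cc1` — 7700 nM
compound 2 `CCOC(=O)[C@H]1CCN(S(=O)(=O)c2ccc(S(=O)(=O)N(CC)CC)cc2)C1` — 29300 nM
compound 3 `CCOC(=O)[C@@H]1CCCN(S(=O)(=O)c2ccc(S(=N)(=O)N(CC)CC)cc2)C1` — 3600 nM

Three compounds sharing the bis-sulfonyl aryl core have numbers in a functional assay on BXPC-3 cells (Homo sapiens) for inhibition, read by MTT assay, with a stated time of 7 days; a lower number here means a stronger inhibitor, a higher number a weaker inhibitor. Compound 1 gives 7700 nM and stands second highest of the three. Compound 3 sits nearest with 3600 nM, a gap beyond the scatter; compound 2 sits furthest with 29300 nM, also beyond the scatter. Going by the values given here, none of these pairs differs in one place only, so no single-change step can be drawn from them; the two values in each pair are simply what they show.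

Compound 4 `CCN(CC)S(=O)(=O)c1ccc(S(=O)(=O)N2CCC[C@@H](c3cc(C)no3)C2)cc1` is the next candidate. It keeps the core of compound 1 and changes one group:

3-methyl-1,2-oxazol-5-yl in place of isopropyl(methyl)carbamoyl on a saturated ring carbon

Among the compounds with values here, with no comparable step among the measured compounds, the size of this change in this assay cannot be read from data. The carbamoyl and the oxazole occupy the same place on the saturated ring, and the compound 3 value sits within reach of compound 1, so a step from compound 1 to compound 4 of a 1.3-fold lower number from compound 1 to compound 4 (0.11 log units; within the scatter) is expected, leaning towards no change beyond the scatter. Compound 4 is estimated at 6000 nM, with a range from 1500 nM to 25000 nM.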

Compound 4, half-maximal inhibitory concentration: 7700 nM
The estimate for compound 4 lay 1.3-fold (0.11 log units) below the measured number; the measured number falls inside the stated range.
By their numbers in this assay, from the lowest: compound 3; then compounds 1 and 4 (each within the scatter of the next); then compound 2.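

In this assay the swap shows no change at the digits printed from compound 1 to compound 4 (within the scatter) and is the only single-change step among the compounds shown, so something can now be said about this place on the saturated ring, two ring bonds from the ring nitrogen. Here 3-methyl-1,2-oxazol-5-yl stands in for isopropyl(methyl)carbamoyl with no shift beyond the scatter, even though an open group without a ring gives way to a five-membered aromatic ring with 2 hetero atoms. The carbonyl of the carbamoyl is therefore not needed to hold the number at this place in this core, though the step says nothing on why the two groups read alike, and no measurement at hand bears on that question.

Going by these compounds alone, compounds 2 and 3 differ from the others in more than one place, so no steps to them can be read, and the oxazole's effect on the ester-bearing cores stays unknown. Also open, going by these compounds, is how far this place accepts change: a primary amine, a carboxylic acid or a longer alkyl chain on the same ring carbon would test whether the flat response extends beyond these two groups.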